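Chloro for methyl on the core: compound 4

A few compounds are considered here, and "the series" means these few. Any claim that something is new, unique, unknown or untested is made for them only; others in the source may bear on it.

Compound 1 `COC(=O)[C@H](CSC)NC(=O)c1cnc2ccccc2c1Cl` gives 68.4 uM in an ADME assay on CCRF-CEM cells (Homo sapiens) for cytotoxicity; on this read-out lower numbers stand for higher toxicity in this test and higher numbers for lower toxicity in this test. For compound 2 `COC(=O)[C@H](CO)NC(=O)c1cnc2ccccc2c1Cl` this assay reports only a limit, > 100 uM. Compound 3 `COC(=O)[C@H](CO)NC(=O)c1cnc2c(C)cccc2c1Cl` likewise reaches only a limit in this assay, > 100 uM. The measured steps are an at least 1.4-fold higher number from compound 1 to compound 2 (0.16 log units; that floor lies within the scatter) and a step that the two limits leave unreadable from compound 2 to compound 3; because the limit of > 100 uM in this assay, at which 2 of the 3 values shown sit, neither the second step nor the standing of compound 3 can be read as a number, and compound 3 sits at the limit together with compound 2. Compound 4 `COC(=O)[C@H](CO)NC(=O)c1cnc2c(Cl)cccc2c1Cl` is not yet measured; it differs from compound 3 by chloro in place of methyl on an aromatic carbon. Among the compounds with values here, no measured step involves a chloro group; the one step on an aromatic carbon, methyl in place of hydrogen, is unreadable, and the step on the saturated chain carbon lies within the scatter at its floor. The expected step is therefore a number no higher from compound 3 to compound 4 (the limit leaves the size open), none beyond the scatter, with a limit the likeliest outcome in this assay. Compound 4 is estimated at 100 uM, within 50 uM to 300 uM.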

Compound 4, half-maximal toxic concentration: > 100 uM
Compound 4 was reported as a limit (the forecaster's own chance of this, stated with the estimate: 70%); the middle value sits exactly at the limit.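

Compound 4, like compound 2 and compound 3, gives only a limit in this assay, so neither step to compound 4 can be read: the limit of > 100 uM in this assay, at which 3 of the 4 values shown sit.

The compounds shown leave open whether hydrogen, methyl and chloro on that aromatic carbon differ at all in this assay.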